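The source may hold more compounds than are shown below. What is called first, only, known or untested is meant among the compounds shown, and "the series" means these compounds.

In an ADME assay on microsomes from liver (Homo sapiens) for metabolic stability (a lower number here means that the compound disappears faster, a higher number that the compound lasts longer), compound 1 `CC(C)C(Cc1nnc[nH]1)c1ccc(-c2ccc3cccc(F)c3c2)[nH]c1=O` gives 0.307 h, which stands highest of the two numbers shown; its nearest neighbour is compound 2 `CC(C)C(c1ccc(-c2ccc3cccc(F)c3c2)[nH]c1=O)N1CCCCC1=O`, which in this assay gives 0.183 h, and the step of a 1.7-fold lower number from compound 1 to compound 2 (0.22 log units; within the scatter) lies within the scatter. Compound 3 `CC(C)C(c1ncc[nH]1)c1ccc(-c2ccc3cccc(F)c3c2)[nH]c1=O` in this assay gives only a limit, < 0.0667 h, which is the limit of < 0.0667 h in this assay, at which 1 of the 3 values shown sits. Compound 4 `CC(C)C(/C=C1\CCNC1=O)c1ccc(-c2ccc3cccc(F)c3c2)[nH]c1=O` has not yet been measured in this assay. Compound 4 differs from compound 1 as follows: a group of 7 heavy atoms (5 carbon, 1 nitrogen, 1 oxygen; one five-membered non-aromatic ring with 1 hetero atom) in place of a group of 6 heavy atoms (3 carbon, 3 nitrogen; one five-membered aromatic ring with 3 hetero atoms), on a saturated chain carbon bound to an aromatic carbon and a saturated chain carbon. The measured steps that bear on this change are a 1.7-fold lower number from compound 1 to compound 2 (0.22 log units; within the scatter) and an at least 4.6-fold lower number from compound 1 to compound 3 (0.66 log units; beyond the scatter), alongside an at least 2.7-fold lower number from compound 2 to compound 3 (0.43 log units; beyond the scatter). The group that enters in compound 4 is, like the group in compound 2, a non-aromatic ring with one hetero atom carrying a carbonyl, so the nearer guide is the small step from compound 1 to compound 2 rather than the larger drop seen for compound 3. Compound 4 is therefore expected to show a step of a 1.5-fold lower number from compound 1 to compound 4 (0.19 log units; within the scatter), at most a modest lowering. The half-life of compound 4 in this assay is estimated at 0.2 h, within a range from 0.08 h to 0.5 h.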

Compound 4, half-life: 0.713 h
Estimate against measurement, compound 4: 3.6-fold (0.55 log units) below; measured number above the stated range.
By their numbers in this assay, from the lowest: compounds 2 and 1 (each within the scatter of the next); then compound 4. At a limit, below all of these: compound 3.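

In this assay, a change at this saturated chain carbon can do more than hold or lower the number: the non-aromatic ring of compound 4 gives a 2.3-fold higher number from compound 1 to compound 4 (0.37 log units; beyond the scatter). Two groups with the same heavy atoms, one a five-membered and the other a six-membered non-aromatic ring, are not interchangeable here either, with a 3.9-fold higher number from compound 2 to compound 4 (0.59 log units; beyond the scatter). The widest span is to the 1H-imidazol-2-yl group, with an at least 10-fold higher number from compound 3 to compound 4 (1.02 log units; beyond the scatter), and it rests on a value for compound 3 that is a limit: the limit of < 0.0667 h in this assay, at which 1 of the 4 values shown sits.

The compounds shown do not separate the ring size of compound 4 from its double bonds outside aromatic rings. From the compounds shown here alone, whether an open-chain amide, an amine or a carboxylic acid at this carbon would give a number as high as that of compound 4 also stays open.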